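Working notes on a small growth-inhibition series

This account rests on a few compounds, and the source may have more. Where it says the series, first, only, none or still open, it means among the compounds named here.

Measured so far:
compound 1, `O=c1cc(-c2ccccc2)oc2ccc(N3COc4c(cccc4[N+](=O)[O-])C3)cc12`: 72.9%
compound 2, `Cc1cc(C)c2c(c1)CN(c1ccc3c(=O)cc(-c4ccccc4)oc3c1)CO2`: 48.4%

In a functional assay on MCF7 cells (Homo sapiens) for inhibition, read by MTT assay, with a stated time of 48 h, tested at 60 ug/mL (on this read-out higher numbers stand for more inhibition of growth at the one concentration tested and lower numbers for less inhibition of growth), compound 1 gives 72.9% and stands highest of the two numbers measured. Compound 2 gives 48.4%, a gap to compound 1 that lies beyond the scatter. For the measured compounds named here, no pair of measured compounds differs in a single place, so the effect of any one change on the shared core has not been isolated.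

Compound 3, `O=c1cc(-c2ccccc2)oc2ccc(N3COc4ccccc4C3)cc12`, is not yet measured. It differs from compound 1 as follows: hydrogen in place of nitro on an aromatic carbon. Going by the values given here, with no measured single-place step to rest on, a moderate change in this assay is expected, most likely downward, as compound 2 at 48.4% shows that other substitution on this part of the core can give a lower number. The expected step is a number 12.9 percentage points lower from compound 1 to compound 3 (beyond the scatter), near the edge of the scatter. Compound 3 is estimated to give 60%, in the range 42% to 76%.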

Compound 3, percent growth inhibition at one concentration: 92.7%
Compound 3: the middle estimate sits 32.7 percentage points below what was measured; the whole stated range lies below it.
By their numbers in this assay, from the lowest: compound 2; then compound 1; then compound 3.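

For the compounds shown here, the step gives the first single-place reading: in this assay the nitro group on this aromatic carbon is not needed for growth inhibition, since hydrogen in its place gives a higher number (a number 19.8 percentage points higher from compound 1 to compound 3 (beyond the scatter)). At this position of the shared core, the compound without nitro therefore carries more inhibition at the one concentration tested, and the change is beyond the scatter. No measured evidence bears on why the number rises with this change.

A single step leaves open whether the rise is particular to nitro or whether any group on this carbon would lower the number, and an amine, a methoxy group or a chlorine atom there would help separate the two readings. Going by these compounds, whether the same step holds on the other positions of the shared core also remains open.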